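The source may hold more compounds than are shown below. What is called first, only, known or untested is meant among the compounds shown, and "the series" means these compounds.

In an assay on isolated protein for binding affinity to melatonin receptor type 1A (Homo sapiens) (on this read-out higher numbers stand for weaker inhibition and lower numbers for stronger inhibition), the measured compounds are:

compound 1, `CCCC(=O)Nc1ccc(Nc2cccc(OC)c2)cc1`, which gives 31 nM;
compound 2, `COc1cccc(Nc2ccc(NC(=O)C(C)C)cc2)c1`, which reaches only a limit of the assay, > 500 nM;
compound 3, `COc1cccc(Nc2ccc(NC(=O)C3CC3)cc2)c1`, which gives 61 nM.

Compound 3 and compound 1 lie within the usual scatter of each other, the step being a 2.0-fold higher number from compound 1 to compound 3 (0.29 log units; within the scatter). Compound 2 stands apart at the limit of > 500 nM in this assay, at which 1 of the 3 values shown sits. The two steps that go beyond the scatter both concern the group on the carbonyl carbon: an at least 16-fold higher number from compound 1 to compound 2 (1.20 log units; beyond the scatter) is large, and an at least 8.1-fold lower number from compound 2 to compound 3 (0.91 log units; beyond the scatter) is at least modest.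

Compound 4, `COc1cccc(N(C)c2ccc(NC(=O)C3CC3)cc2)c1`, is not yet measured. It differs from compound 3 in one place: methyl in place of hydrogen on a nitrogen on an aromatic ring. None of the three measured steps touches that nitrogen; all of them exchange the group on the carbonyl carbon while leaving the rest of the shared core untouched. Within the data shown here, there is therefore no direct precedent among the measured compounds for this change, and the expectation for compound 4 rests only on compound 3 as its nearest neighbour. The step of a 1.8-fold higher number from compound 3 to compound 4 (0.26 log units; within the scatter) is expected to be small, with a wide range on either side. The value of compound 4 in this assay is estimated at 110 nM, between 30 nM and 450 nM.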

Compound 4, inhibition constant: 12 nM
Compound 4: the middle estimate sits 9.2-fold (0.96 log units) above what was measured; measured number outside the range, below it.
By their numbers in this assay, from the lowest: compound 4; then compounds 1 and 3 (each within the scatter of the next). At a limit, above all of these: compound 2.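

Among these compounds, the first change at this nitrogen gives, in this assay, a 5.1-fold lower number from compound 3 to compound 4 (0.71 log units; beyond the scatter), a modest step that goes beyond the scatter. Among the compounds shown here, all the earlier steps exchanged the group on the carbonyl carbon, so they showed only that this part of the molecule was sensitive to the choice of group; this step shows that the nitrogen on an aromatic ring is a second place where one change moves the number, and that a hydrogen on it is not needed for a low number with cyclopropyl on the carbonyl carbon. Nothing measured here bears on the cause of this step.

The compounds shown leave open whether methyl on this nitrogen would lower the number in the same way with propyl or isopropyl on the carbonyl carbon, since the step is seen with cyclopropyl alone. They also leave open how far the nitrogen accepts anything larger, such as an ethyl group, a longer chain or an acetyl group, as only hydrogen and methyl appear there.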